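The compounds below may be only part of what the source reports. "The series", "measured", "known", "first", "only" and "open" are said of these compounds alone.

Measured so far in a toxicity assay on A-375 cells (Homo sapiens) for cytotoxicity, read by CCK-8 assay, with stated times of 16 h and 24 h; a lower number here means a stronger inhibitor, a higher number a weaker inhibitor:

- compound 1 `COc1ccc(C2=[N+]3C(=Nc4c(-c5ccccc5)c5c(n4[B-]3(F)F)-c3ccc(OCC(=O)O)cc3CC5)C(c3ccccc3)=C2I)cc1`: 142 nM
- compound 2 `COc1ccc(C2=[N+]3C(=Nc4c(-c5ccccc5)c5c(n4[B-]3(F)F)-c3ccc(OCC(=O)N[C@@H](CCC(=O)O)C(=O)O)cc3CC5)C(c3ccccc3)=C2I)cc1`: 166 nM
- compound 3 `COc1ccc2c(c1)CCc1c(-c3ccccc3)c3n(c1-2)[B-](F)(F)[N+]1=C(c2ccc(OCC(=O)O)cc2)C(I)=C(c2ccccc2)C1=N3`: 320 nM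

Compound 3 gives 320 nM and so has a higher number, meaning a weaker inhibitor, than compound 1 at 142 nM, a gap beyond the usual scatter. Compound 3 and compound 2 lie within the scatter of each other.

The next compound, compound 4 `COc1ccc2c(c1)CCc1c(-c3ccccc3)c3n(c1-2)[B-](F)(F)[N+]1=C(c2ccc(OCC(=O)N[C@@H](CC(=O)O)C(=O)O)cc2)C(I)=C(c2ccccc2)C1=N3`, differs from compound 3 in one place: (1,2-dicarboxyethyl)amino in place of hydroxy on a carbonyl carbon. In words, this is (1,2-dicarboxyethyl)amino in place of hydroxy on a carbonyl carbon.

Within the data shown here, one measured step bears on this change. It is a 1.2-fold higher number from compound 1 to compound 2 (0.07 log units; within the scatter), which stays within the scatter and swaps hydroxy on a carbonyl carbon for (1,3-dicarboxypropyl)amino. That group is a close relative of the incoming one, not the same group, and the step was measured on a differently arranged compound, so it is only a guide. Among the measured compounds shown here, no measurement yet shows the (1,2-dicarboxyethyl)amino group itself.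

In this assay the expected result is therefore no step beyond the scatter, and the estimated change is a 1.1-fold higher number from compound 3 to compound 4 (0.03 log units; within the scatter).

For compound 4 the estimated value is 340 nM, with an expected range from 170 nM to 680 nM.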

Compound 4, half-maximal inhibitory concentration in the A-375 assay: 148 nM
For compound 4 the middle estimate is 2.3-fold (0.36 log units) above the measured one; measured number outside the range, below it.
By their numbers in the A-375 assay, from the lowest: compounds 1, 4, 2 and 3 (each within the scatter of the next, the first and the last beyond it).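

In the A-375 assay, putting (1,2-dicarboxyethyl)amino in place of hydroxy on this carbonyl carbon gives a stronger inhibitor, a 2.2-fold lower number from compound 3 to compound 4 (0.33 log units; beyond the scatter), so the position does respond to this kind of change. The close relative (1,3-dicarboxypropyl)amino, on the differently arranged compound, stayed within the scatter, a 1.2-fold higher number from compound 1 to compound 2 (0.07 log units; within the scatter), so swapping hydroxy for such a group does not have the same outcome in every setting. In a physicochemical assay for lipophilicity (on this read-out higher numbers stand for higher lipophilicity and lower numbers for lower lipophilicity), compound 3 gives 0.92 and compound 4 gives -0.73. In the physicochemical assay the new step adds a second measured shift, although this single pair cannot show that the lower lipophilicity is what strengthens inhibition: the measured partition coefficient of compound 3, 0.92, and of compound 4, -0.73, a number 1.65 log units lower (beyond the scatter)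

From the compounds shown here alone, whether the different outcomes come from the two groups themselves or from the arrangement of the core stays open, since the two steps differ in both. A carboxymethylamino group on the same carbonyl carbon, carrying a single carboxylic acid in its side chain, would help show whether both carboxylic acids of (1,2-dicarboxyethyl)amino are needed for the stronger inhibition.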